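A Single Fluoro Change on Compound 2

A few compounds are considered here, and "the series" means these few. Any claim that something is new, unique, unknown or untested is made for them only; others in the source may bear on it.

In a functional assay on SK-MEL-28 cells (Homo sapiens) for inhibition, read by colorimetric assay and MTT assay, with a stated time of 72 h (on this read-out lower numbers stand for stronger inhibition and higher numbers for weaker inhibition), compound 1 `Cn1c2cnc1OCCCCCCCCCCOc1cc3ccccc3cc1-2` gives 33000 nM. In this assay compound 2 `C=CCCCCOc1ccccc1-c1cnc(OCCC=C)n1C` gives 17000 nM, and the two numbers lie within the scatter of each other, so neither compound can be ranked over the other. Compound 3 `C=CCCCCOc1ccc(F)cc1-c1cnc(OCCC=C)n1C` departs from compound 2 at one place, with fluoro in place of hydrogen on an aromatic carbon, para to a (hex-5-en-1-yl)oxy group: fluoro in place of hydrogen on an aromatic carbon. No measured pair differs in one place only, so the size of this change has not been shown directly. With compound 2 at 17000 nM as the only starting point, no shift beyond the scatter is expected in this assay, at most a slight drift toward lower numbers. The expected move is a 1.2-fold lower number from compound 2 to compound 3 (0.08 log units; within the scatter). For compound 3 the estimated value is 14000 nM, with an expected range from 6000 nM to 32000 nM.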

Compound 3, half-maximal inhibitory concentration: 82000 nM
For compound 3 the middle estimate is 5.9-fold (0.77 log units) below the measured one; the whole stated range lies below it.
By their numbers in this assay, from the lowest: compounds 2 and 1 (each within the scatter of the next); then compound 3.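

In this assay, the aromatic carbon para to a (hex-5-en-1-yl)oxy group proves sensitive to this change: fluoro in place of hydrogen there gives a 4.8-fold higher number from compound 2 to compound 3 (0.68 log units; beyond the scatter). Among these compounds, this is the first single-place change that can be read, and it shows that one added fluorine at this position moves the number upward, toward weaker inhibition, which compounds 1 and 2 alone could not show. Nothing available accounts for the direction of this step.

Whether the step belongs to fluoro itself or would follow any replacement of hydrogen here stays open, since chloro, methyl and methoxy at this position are not among the compounds shown. The compounds shown also leave open whether the same fluoro change would act alike on the core of compound 1.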